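A few compounds are considered here, and "the series" means these few. Any claim that something is new, unique, unknown or untested is made for them only; others in the source may bear on it.

compound 1 `O=C(N/N=C/c1ccc(F)cc1Cl)Nc1cc2c(Nc3ccc(F)c(Cl)c3)ncnc2cc1O[C@H]1CCOC1`: 32200 nM
compound 2 `O=C(N/N=C/c1cccc(Cl)c1Cl)Nc1cc2c(Nc3ccc(F)c(Cl)c3)ncnc2cc1O[C@H]1CCOC1`: "not active" (no number reported)

Both compounds were tested in a functional assay on MCF7 cells (Homo sapiens) for cytotoxicity, read by MTT assay, with a stated time of 72 h; a higher number here means a weaker inhibitor, a lower number a stronger inhibitor. Compound 2 has no number on this scale, as it was reported only as "not active" (no number reported). The next compound to be tested is compound 3 `COc1ccc(/C=N/NC(=O)Nc2cc3c(Nc4ccc(F)c(Cl)c4)ncnc3cc2O[C@H]2CCOC2)c(OC)c1OC`. The structural change is 2,3,4-trimethoxyphenyl in place of 2,3-dichlorophenyl on a carbon with a double bond to nitrogen: 2,3,4-trimethoxyphenyl comes in place of 2,3-dichlorophenyl on a carbon with a double bond to nitrogen. For the measured compounds named here, no measured step shows what a change of this kind does in this assay, so the expectation is only a rough one. Going by the values given here, a modest step towards a stronger reading is expected, enough to give a measurable number but not a potent one, because compound 1 gives 32200 nM and is the only numerical guide. For compound 3 the expected value is 30000 nM, with an estimated range of 10000 nM to 80000 nM.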

Compound 3, half-maximal inhibitory concentration: 33800 nM
For compound 3 the middle estimate is 1.1-fold (0.05 log units) below the measured one, and the stated range covers the measured number.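

In this assay, putting 2,3,4-trimethoxyphenyl in place of 2-chloro-4-fluorophenyl on a carbon with a double bond to nitrogen gives a 1.0-fold higher number from compound 1 to compound 3 (0.02 log units; within the scatter) and so shows that a measurable reading at this place does not require halogens on the ring. Compound 2, with its 2,3-dichlorophenyl group, was reported only as "not active", so a halogen-bearing ring does not guarantee a number, and the gap between that compound and compound 3 has no size that can be read. Nothing given here explains why these compounds read as they do.

As far as these compounds go, it remains open whether a non-aromatic group, such as cyclohexyl, would give a reading in the same range. From the compounds shown here alone, it is also open whether a phenyl ring carrying an amine or a carboxylic acid would give a lower number.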